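Two limit readings and one open hydrazone

The source may report more compounds than this note shows. Statements on the series, on what has been measured and on what is new or still open speak of the compounds shown alone.

Measured in a functional assay on NCI-H460 cells (Homo sapiens) for cytotoxicity, read by sulforhodamine B assay; a lower number here means that less compound is tolerated, a higher number that more compound is tolerated:
- compound 1 `CC1=CC[C@@H]([C@@](C)(O)CCCC(C)(C)NC(=S)NN)CC1`: > 100000 nM (a limit)
- compound 2 `CC1=CC[C@@H]([C@@](C)(O)CCCC(C)(C)NC(=S)N/N=C\c2ccccc2[N+](=O)[O-])CC1`: > 100000 nM (a limit)

Compound 2 gives no number, only the limit (> 100000 nM). The same holds across the short series, which shows (the limit of > 100000 nM in this assay, at which 2 of the 2 values shown sit). Neither measured compound therefore offers a step that could be sized.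

The next compound, compound 3 `CC1=CC[C@@H]([C@@](C)(O)CCCC(C)(C)NC(=S)N/N=C\c2ccc(Cl)cc2)CC1`, carries 4-chlorophenyl in place of 2-nitrophenyl on a carbon with a double bond to nitrogen. The rest of the structure stays as in compound 2.

Among the compounds with values here, with no measured step to draw on, the expectation rests on the structural change and on the limit of compound 2 (> 100000 nM). A small move towards less compound tolerated in this assay is expected, and another limit reading is about as likely as a number. The expected step is estimated as (an at least 1.4-fold lower number from compound 2 to compound 3 (0.15 log units; that floor lies within the scatter)). For compound 3 the estimated value is 70000 nM, with an expected range from 20000 nM to 200000 nM.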

Compound 3, concentration lethal to 50% of the cells: > 100000 nM
Compound 3 gave a limit, no number; the forecaster's own chance of this, stated with the estimate: 55%; at least 1.4-fold (0.15 log units) between middle value and limit.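

Compound 3, like compound 1 and compound 2, reads only as a limit in this assay and so the steps from compound 1 and from compound 2 to compound 3 cannot be read: the limit of > 100000 nM in this assay, at which 3 of the 3 values shown sit.

The compounds shown leave open how far each lies from that limit and which structural change, if any, would give a numerical reading.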